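Chloro for Ethyl on a Urea Side Chain

The source may hold more compounds than are shown below. What is called first, only, known or untested is meant among the compounds shown, and "the series" means these compounds.

Three compounds have so far been measured in a functional assay on MCF7 cells (Homo sapiens) for antiproliferative activity, read by sulforhodamine B assay, with a stated time of 48 h; a higher number here means a weaker inhibitor, a lower number a stronger inhibitor:

Compound 1, `CCCCCC(=O)Nc1ccc(S(=O)(=O)Oc2ccccc2C(C)C)cc1`, gives 5300 nM.
Compound 2, `CC(C)c1ccccc1OS(=O)(=O)c1ccc(NC(=O)CCCCl)cc1`, gives 5200 nM.
Compound 3, `CCCCCNC(=O)Nc1ccc(S(=O)(=O)Oc2ccccc2C(C)C)cc1`, gives 4000 nM.

Compound 2 differs from compound 1 by chloro in place of ethyl on a saturated chain carbon, three bonds along the chain from a carbonyl carbon, and this change produced a 1.0-fold lower number from compound 1 to compound 2 (0.01 log units; within the scatter). Compound 3 differs from compound 1 by pentylamino in place of pentyl on a carbonyl carbon, giving a 1.3-fold lower number from compound 1 to compound 3 (0.12 log units; within the scatter). Between compound 2 and compound 3 the data show a 1.3-fold lower number from compound 2 to compound 3 (0.11 log units; within the scatter). All three numbers therefore sit in one band, and none of the three compounds can be singled out as stronger or weaker than the others.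

Compound 4, `CC(C)c1ccccc1OS(=O)(=O)c1ccc(NC(=O)NCCCCl)cc1`, has not yet been measured in this assay. It differs from compound 3 by chloro in place of ethyl on a saturated chain carbon, three bonds along the chain from an amide-type nitrogen. For the measured compounds named here, this is the same kind of change as the one from compound 1 to compound 2, though the surroundings of the place differ: in the earlier pair the saturated chain carbon lies three bonds along the chain from a carbonyl carbon, whereas in the new pair it lies three bonds along the chain from an amide-type nitrogen. The two cores themselves differ by pentylamino in place of pentyl on a carbonyl carbon.

For compound 4 the step of no change at the digits printed from compound 3 to compound 4 (within the scatter) is expected because a 1.0-fold lower number from compound 1 to compound 2 (0.01 log units; within the scatter) shows that the earlier exchange of ethyl for chloro left the number essentially where it was. Compound 4 is therefore estimated at 4000 nM, with a range from 2200 nM to 7500 nM.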

Compound 4, half-maximal inhibitory concentration: 7400 nM
Compound 4: the middle estimate sits 1.9-fold (0.27 log units) below what was measured, and the stated range covers the measured number.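

In this assay, chloro in place of ethyl on the core of compound 3 gave a 1.9-fold higher number from compound 3 to compound 4 (0.27 log units; within the scatter), and the same change read on the two cores does not separate: the same change on two cores in this assay, a 1.0-fold lower number (0.01 log units; within the scatter) from compound 1 to compound 2 and a 1.9-fold higher number (0.27 log units; within the scatter) from compound 3 to compound 4, 1.9-fold (0.28 log units) apart, within the scatter of two such steps. The other two new steps, a 1.4-fold higher number from compound 2 to compound 4 (0.15 log units; within the scatter) and a 1.4-fold higher number from compound 1 to compound 4 (0.14 log units; within the scatter), also stay inside the scatter, so all four compounds sit in one band and none can be called stronger or weaker than another. This shows that the exchange of ethyl for chloro carried from one core to the other without a difference that these measurements can resolve, but it does not show that the two steps are identical, as a real gap smaller than the scatter would go unseen, and two pairs that both stay within the scatter cannot show how the change would carry where it had a larger effect.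

The compounds shown leave open whether a different group at the end of the chain, such as a hydroxyl, an amine or a carboxylic acid, would move the number beyond the scatter. They also leave open whether chloro on a shorter or a longer chain would behave as it does on these two cores.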